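The compounds below may be only part of what the source reports. "The series", "measured", "known", "first", "only" and "open" are said of these compounds alone.

In an assay on isolated protein for inhibition of Amine oxidase [flavin-containing] A (Homo sapiens), read by fluorescence, with a stated time of 30 min, tested at 20 uM (a higher number here means more inhibition at the concentration tested (going by the name of the read-out), a lower number less inhibition), the measured compounds stand as follows: compound 1 `COc1cc2c(cc1OC)C(=O)/C(=C/c1ccc(CN3CCCC3)c(O)c1)CO2` gives 16.4%; compound 2 `COc1cc2c(cc1OC)C(=O)/C(=C/c1ccc(CN(C)Cc3ccccc3)c(O)c1)CO2` gives 3.4%; compound 3 `CCN(CC)Cc1c(O)cccc1/C=C1\COc2cc(OC)c(OC)cc2C1=O` gives 8.5%.

Compound 3 sits between the other two numbers, and both gaps lie within the usual scatter: compound 2 is lower by an amount inside the scatter, compound 1 higher by an amount inside it. Nothing in this set separates compound 3 from the others.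

Compound 4 `CCN(Cc1ccccc1)Cc1c(O)cccc1/C=C1\COc2cc(OC)c(OC)cc2C1=O` is the next member. It differs from compound 3 by phenyl in place of methyl on a saturated chain carbon bound to an amine nitrogen. Among the compounds with values here, one measured step bears on this: adding a benzyl group on the amine nitrogen in place of a ring, a number 13 percentage points lower from compound 1 to compound 2 (beyond the scatter), a modest fall beyond the scatter. That step changes the amine in a different way, so it is a rough guide only, but it points downward. With compound 3 already low, the room for a further fall is small, so only a small drop, or none beyond the scatter, is expected, written as a number 4.5 percentage points lower from compound 3 to compound 4 (within the scatter). Compound 4 is therefore estimated at 4% in this assay, with a range from 0% to 13%.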

Compound 4, a percentage reported as inhibition, at one concentration (the size of the read-out at that concentration, not a potency): 9.8%
Estimate against measurement, compound 4: 5.8 percentage points below, and the stated range covers the measured number.
By their numbers in this assay, from the lowest: compounds 2, 3, 4 and 1 (each within the scatter of the next, the first and the last beyond it).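

In this assay, phenyl in place of methyl on a saturated chain carbon bound to an amine nitrogen gives a number 1.3 percentage points higher from compound 3 to compound 4 (within the scatter), so diethylamino and benzyl(ethyl)amino cannot be told apart at this position. Within the data shown here, the earlier change of pyrrolidin-1-yl to benzyl(methyl)amino gave a number 13 percentage points lower from compound 1 to compound 2 (beyond the scatter), and compound 4 now goes against any reading that a benzyl group on the amine nitrogen brings a lower number in every case: only that earlier step lies beyond the scatter, and the two steps start from different amines on different compounds. No measurement at hand accounts for either step.

Open, as far as these compounds go, is whether pyrrolidin-1-yl on the core of compound 3 would give a number like that of compound 1, and what a piperidin-1-yl or morpholin-4-yl group, or a longer chain in place of ethyl, would give on this amine nitrogen. With one tested concentration, the read-out gives no potency for any of these compounds, so how they would rank at other concentrations also remains unsettled.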